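Cyclobutyl to aminomethyl on the amide of compound 3

The source may report more compounds than this note shows. Statements on the series, on what has been measured and on what is new or still open speak of the compounds shown alone.

Compound 3 `COc1nc(N2CCN(C)CC2)nc(OC)c1Sc1cccc(NC(=O)C2CCC2)c1` gives 70 uM in a functional assay on SK-BR-3 cells (Homo sapiens) for cytotoxicity, read by resazurin assay, with a stated time of 72 h (a lower number here means a stronger inhibitor of growth, a higher number a weaker inhibitor of growth), the highest number of the three measured. Its nearest neighbour is compound 2 `COc1nc(N2CCN(C)CC2)nc(OC)c1Sc1nccc(NC(=O)C2CC2)n1` at 15 uM, a gap beyond the scatter; compound 1 `C=CC(=O)Nc1ccnc(Sc2c(C)nc(N3CCN(C)CC3)nc2C)n1`, with a different core, gives 1.8 uM, the furthest from compound 3. Compound 4 `COc1nc(N2CCN(C)CC2)nc(OC)c1Sc1cccc(NC(=O)CN)c1` keeps the core of compound 3 and changes only the amide: aminomethyl in place of cyclobutyl on a carbonyl carbon. Among the measured compounds shown here, no measured pair shows this change, so nothing fixes its size. Against that background the expectation for the step is a 1.1-fold higher number from compound 3 to compound 4 (0.06 log units; within the scatter), a movement no larger than the scatter in either direction. Compound 4 is estimated at 80 uM, within 25 uM to 250 uM, the wide range reflecting the absence of any comparable step.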

Compound 4, concentration for growth inhibition (reported as GI): 25 uM
For compound 4 the middle estimate is 3.2-fold (0.51 log units) above the measured one; the measured number falls inside the stated range.
By their numbers in this assay, from the lowest: compound 1; then compounds 2 and 4 (each within the scatter of the next); then compound 3.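

In this assay, among the compounds shown here, the amide of this core is not a silent position: aminomethyl in place of cyclobutyl on a carbonyl carbon gives a 2.8-fold lower number from compound 3 to compound 4 (0.45 log units; beyond the scatter), a modest step beyond the scatter and the first single-place comparison. It shows that the cyclobutyl ring is not needed for growth inhibition at this level on this core.

The compounds shown do not separate loss of the ring from gain of the amine, which a plain methyl or a longer aminoethyl chain on the same carbonyl would address. No supporting measurement bears on the origin of this step.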